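Swapping a chain group for a five-membered ring

The compounds below may be only part of what the source reports. "The series", "measured", "known", "first", "only" and "open" are said of these compounds alone.

- Compound 1: `COc1cc(O)c(C(=O)OCC(C)c2ccccc2)c(/C=C/CN2C(=O)C=CC2=O)c1`, 3380 nM
- Compound 2: `C/C=C/C(=O)NC/C=C/c1cc(OC)cc(O)c1C(=O)OC(C)C`, > 10000 nM (a limit of the assay)

These two values come from a functional assay on MV4-11 cells (Homo sapiens) for antiproliferative activity, read by luminescence, with a stated time of 72 h; on this read-out lower numbers stand for stronger inhibition and higher numbers for weaker inhibition. Compound 2 stands at the limit of > 10000 nM in this assay, at which 1 of the 2 values shown sits. Its entry is a limit and not a number, so no exact strength can be given for it.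

Compound 3 `COc1cc(O)c(C(=O)OC(C)C)c(/C=C/CN2C(=O)C=CC2=O)c1` has not yet been measured, and it differs from compound 2 in one place: a group of 7 heavy atoms (4 carbon, 1 nitrogen, 2 oxygen; one five-membered non-aromatic ring with 1 hetero atom) in place of a group of 6 heavy atoms (4 carbon, 1 nitrogen, 1 oxygen; no ring), on a saturated chain carbon bound to a double-bonded chain carbon. The change lies on a saturated chain carbon bound to a double-bonded chain carbon. The group that enters, with its five-membered non-aromatic ring, is also carried by compound 1, which gives 3380 nM. Going by the values given here, compound 1 differs from compound 3 elsewhere as well, and no measured pair isolates this change, so that value is only a rough guide.

Stronger inhibition beyond the usual scatter is expected in this assay, with an estimated at least 3.3-fold lower number from compound 2 to compound 3 (0.52 log units; beyond the scatter). For compound 3 the expected value is 3000 nM, with an estimated range from 800 nM to 10000 nM.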

Compound 3, half-maximal inhibitory concentration: 1730 nM
The estimate for compound 3 lay 1.7-fold (0.24 log units) above the measured number, and the stated range covers the measured number.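

In this assay, the group with the five-membered non-aromatic ring, placed on a saturated chain carbon bound to a double-bonded chain carbon in place of ((prop-1-en-1-yl)carbonyl)amino, gives an at least 5.7-fold lower number from compound 2 to compound 3 (0.76 log units; beyond the scatter), a change beyond the usual scatter and the first read directly at this position. Compound 2 stands at a limit of the assay and not at a number: the limit of > 10000 nM in this assay, at which 1 of the 3 values shown sits.

The second change, isopropyl in place of 2-phenylpropyl on an oxygen next to a carbonyl group, gives a 2.0-fold lower number from compound 1 to compound 3 (0.29 log units; within the scatter), which lies within the scatter, so compound 1 and compound 3, which both carry the ring group, cannot be told apart and neither of these two groups stands out in this assay.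

The compounds shown do not tell which part of the entering group matters, since a single swap changes the ring, the hydrogen-bond count and the double bonds together, and a simple amine or a fully saturated five-membered ring at the same place would help to separate these. On these data alone, it also remains open whether a carboxylic acid or a longer chain in place of the isopropyl group would stay within the same range.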